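The compounds below may be only part of what the source reports. "The series", "measured", "known", "first", "only" and "open" are said of these compounds alone.

Three compounds share one core, each carrying a different ring on the sulfonyl sulfur. Compound 1 `O=C(/C=C/c1cccc(NS(=O)(=O)c2cccc(Cl)c2)c1)c1nc2ccccc2[nH]1` carries a 3-chlorophenyl there, compound 2 `Cc1ccccc1S(=O)(=O)Nc1cccc(/C=C/C(=O)c2nc3ccccc3[nH]2)c1` a 2-methylphenyl and compound 3 `Cc1cccc(S(=O)(=O)Nc2cccc(/C=C/C(=O)c3nc4ccccc4[nH]3)c2)c1` a 3-methylphenyl. In a functional assay on HCT-116 cells (Homo sapiens) for antiproliferative activity, read by MTT assay, with a stated time of 48 h (on this read-out higher numbers stand for weaker inhibition and lower numbers for stronger inhibition), compound 1 gives 737 nM, compound 2 gives 955 nM and compound 3 gives 597 nM. Compound 3 has the lowest of the three numbers, but its steps to the others are small: a 1.2-fold lower number from compound 1 to compound 3 (0.09 log units; within the scatter) and a 1.6-fold lower number from compound 2 to compound 3 (0.20 log units; within the scatter), both within the scatter, as is a 1.3-fold higher number from compound 1 to compound 2 (0.11 log units; within the scatter).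

Compound 4 `O=C(/C=C/c1cccc(NS(=O)(=O)c2cc(Cl)cc(Cl)c2)c1)c1nc2ccccc2[nH]1` is not yet measured. It differs from compound 3 in one place: 3,5-dichlorophenyl in place of 3-methylphenyl on a sulfonyl sulfur. Among the measured compounds shown here, the one measured step that bears on this change is the exchange of chloro for methyl on that ring, a 1.2-fold lower number from compound 1 to compound 3 (0.09 log units; within the scatter), which stayed within the scatter. For the measured compounds named here, no measured compound carries two chlorines on this ring, so the second chloro is untested. The expected step is therefore small, a 1.1-fold higher number from compound 3 to compound 4 (0.04 log units; within the scatter), with no clear direction. Compound 4 is estimated at 650 nM, within a range from 250 nM to 1700 nM.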

Compound 4, half-maximal inhibitory concentration: 2840 nM
Compound 4: middle estimate off by 4.4-fold (0.64 log units), on the low side; measured number outside the range, above it.
By their numbers in this assay, from the lowest: compounds 3, 1 and 2 (each within the scatter of the next); then compound 4.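

In this assay the ring on the sulfonyl sulfur turns out to matter: the earlier exchanges stayed within the scatter, but adding a second chlorine gives a 3.9-fold higher number from compound 1 to compound 4 (0.59 log units; beyond the scatter) for a change of only chloro in place of hydrogen on an aromatic carbon. The 3,5-dichlorophenyl ring also stands apart from both methyl-bearing rings, with a 4.8-fold higher number from compound 3 to compound 4 (0.68 log units; beyond the scatter) and a 3.0-fold higher number from compound 2 to compound 4 (0.47 log units; beyond the scatter) as the steps, so this position accepts some of the rings shown but not all of them. Nothing measured here explains the weaker inhibition.

Still open, as far as these compounds go, is whether this step belongs to chlorine itself or to any second group on the ring, which a 3,5-dimethylphenyl ring could help separate. From the compounds shown here alone, how a ring bearing a methoxy group or an amine would read also remains unknown.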